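Hydroxyethyl for dimethylaminopropyl on two related cores

The source may report more compounds than this note shows. Statements on the series, on what has been measured and on what is new or still open speak of the compounds shown alone.

Compound 1 `CCCn1c(=O)n(CCCN(C)C)c(=O)c2[nH]cnc21` and compound 2 `CCCn1c(=O)n(CCO)c(=O)c2[nH]cnc21` share one core; compound 3 `CCCn1c(=O)n(C)c(=O)c2c1ncn2CCCN(C)C` and compound 4 `CCCn1c(=O)n(C)c(=O)c2c1ncn2CCO` share another. The difference between the two cores is not broken down here.

In a functional assay (trachea) with Cavia porcellus as the target (on this read-out lower numbers stand for an effect already at smaller amounts and higher numbers for an effect only at larger amounts of compound), compound 1 gives 20500 nM. In this assay compound 2 gives 510 nM. The change between them is hydroxy in place of (dimethylamino)methyl on a saturated chain carbon, two bonds along the chain from an aromatic nitrogen, and it produced a 40-fold lower number from compound 1 to compound 2 (1.60 log units; beyond the scatter).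

For compound 3 the read-out in this assay is a limit, > 100000 nM, and not a number. Compound 3 sits at the limit of > 100000 nM in this assay, at which 1 of the 3 values shown sits.

Compound 4 carries the same change on the core of compound 3, namely (hydroxy in place of (dimethylamino)methyl on a saturated chain carbon, two bonds along the chain from an aromatic nitrogen). Among the measured compounds shown here, the only measured instance of this change is the step from compound 1 to compound 2, a 40-fold lower number from compound 1 to compound 2 (1.60 log units; beyond the scatter), so a step of roughly that direction and size is the working expectation. The starting point for compound 3 is a limit rather than a number, so how far compound 4 may move is less certain than in the first pair, and a part of the expected range stays at the limit. The step expected here is an at least 5.0-fold lower number from compound 3 to compound 4 (0.69 log units; beyond the scatter). For compound 4 the estimate in this assay is 20000 nM, with a range from 3000 nM to 100000 nM.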

Compound 4, half-maximal effective concentration: 31800 nM
The estimate for compound 4 lay 1.6-fold (0.20 log units) below the measured number; measured number inside the range.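

Hydroxy in place of (dimethylamino)methyl, on a saturated chain carbon, two bonds along the chain from an aromatic nitrogen, again lowers the number in this assay, with an at least 3.1-fold lower number from compound 3 to compound 4 (0.49 log units; beyond the scatter). The direction of the change therefore carries over from the core of compound 1 to the core of compound 3 in these two pairs, but the size on the second core is only a lower bound, since compound 3 is recorded as a limit and not as a number: the limit of > 100000 nM in this assay, at which 1 of the 4 values shown sits. Whether the change is equally large on both cores is not shown, and two pairs establish no general rule for the series: the same change on two cores in this assay, a 40-fold lower number (1.60 log units; beyond the scatter) from compound 1 to compound 2 and an at least 3.1-fold lower number (0.49 log units; beyond the scatter) from compound 3 to compound 4; the limit leaves it open whether they differ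

The compounds shown leave open how the chain end behaves on these cores when it carries a carboxylic acid or a primary amine, or when a longer chain carries the hydroxy group. The true size of the step on the core of compound 3 also remains open, as does the effect of the core itself, since no pair shown differs in the core alone.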